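The compounds below may be only part of what the source reports. "The series", "measured", "known", "first", "only" and "open" are said of these compounds alone.

The series is built around an aryl triazene carrying a primary carboxamide, measured for antiproliferative activity in a functional assay on L1210 cells (Mus musculus) for antiproliferative activity; a higher number here means a more potent compound, by a factor of ten per unit of this negative logarithm, a lower number a less potent compound. Compound 1, `CCCCCN(C)/N=N/c1nc[nH]c1C(N)=O`, and compound 2, `CCCN(C)/N=N/c1nc[nH]c1C(N)=O`, share the same core and differ only in the length of the chain on the amine nitrogen. In this assay compound 1 gives 3.58, and compound 2 gives 3.58. The change between them, (ethyl in place of hydrogen on a saturated chain carbon, three bonds along the chain from an amine nitrogen), produced a step of no change at the digits printed from compound 2 to compound 1 (within the scatter).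

Compound 3, `CN(C)/N=N/c1ccccc1C(N)=O`, rests on a different core; the difference between the two cores is not broken down here. In this assay compound 3 gives 3.31, which lies within the scatter of the values of compound 1 and compound 2.

Compound 4, `CCCN(C)/N=N/c1ccccc1C(N)=O`, has not yet been measured. It arises from compound 3 by ethyl in place of hydrogen on a saturated chain carbon bound to an amine nitrogen. Going by the values given here, this is the same kind of change as the one that led from compound 2 to compound 1, though not the same: there the ethyl entered three bonds along the chain from an amine nitrogen, here it enters on a saturated chain carbon bound to an amine nitrogen. Because the earlier step of no change at the digits printed from compound 2 to compound 1 (within the scatter) showed no movement, the step from compound 3 to compound 4 is expected to be small as well, about a number 0.04 log units higher from compound 3 to compound 4 (within the scatter). Compound 4 is therefore estimated at 3.35 in this assay, with the likely range running from 2.95 to 3.75.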

Compound 4, logarithm of the reciprocal of the active concentration, log(1/C): 3.26
For compound 4 the middle estimate is 0.09 log units above the measured one, within the range that was stated.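

In this assay, ethyl in place of hydrogen on a saturated chain carbon bound to an amine nitrogen gave a number 0.05 log units lower from compound 3 to compound 4 (within the scatter) and so left the read-out of compound 4 within the scatter of that of compound 3. Going by these compounds alone, this does not show that the change is silent on every core or at every place on the chain: only two pairs are available, and the ethyl does not sit at the same place in them, since in compound 1 it stands three bonds along the chain from an amine nitrogen. Within those limits, the change carried from the core of compound 1 to the core of compound 3 without a detectable difference between the two steps:  the same change on two cores in this assay, no change at the digits printed (within the scatter) from compound 2 to compound 1 and a number 0.05 log units lower (within the scatter) from compound 3 to compound 4, 0.05 log units apart, within the scatter of two such steps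

The compounds shown leave open whether the flat response persists when the chain on the amine nitrogen carries something other than plain carbon and hydrogen, such as a terminal hydroxyl group or a carboxylic acid, or when it is much longer than the pentyl chain of compound 1. They also leave open whether the same holds when the primary carboxamide on either core gives way to a nitrile or a carboxylic acid.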